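Cyclohexyl to cyclopropyl on the amine of the shared core

This account rests on a few compounds, and the source may have more. Where it says the series, first, only, none or still open, it means among the compounds named here.

Of the compounds shown here, two have been tested in a functional assay on MOLT-4 cells (Homo sapiens) for cytotoxicity, read by MTT assay, with a stated time of 48 h; on this read-out higher numbers stand for weaker inhibition and lower numbers for stronger inhibition. Compound 1 `[O-][n+]1nc(NC2CCCCC2)[n+]([O-])c2ccccc21` gives 1300 nM in this assay. Compound 2 `O=[N+]([O-])c1ccc(CNc2n[n+]([O-])c3ccccc3[n+]2[O-])cc1` gives 800 nM in this assay. Compound 1 stands at the highest of the two numbers, but its gap to compound 2 lies within the scatter, so the two show no difference that can be read as an order. Compound 3 `[O-][n+]1nc(NC2CC2)[n+]([O-])c2ccccc21` has not yet been measured. It differs from compound 1 in one place: cyclopropyl in place of cyclohexyl on a nitrogen on an aromatic ring. Within the data shown here, no measured pair covers a change of this kind, so the step from compound 1 to compound 3 has no precedent in the data. The step of a 1.5-fold higher number from compound 1 to compound 3 (0.19 log units; within the scatter) is expected to be small, probably a mild loss, not clearly beyond the scatter. Compound 3 is estimated at 2000 nM in this assay, with a range from 700 nM to 6000 nM.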

Compound 3, half-maximal inhibitory concentration: 1900 nM
Beside the measured number, compound 3's estimate is 1.1-fold (0.02 log units) above it; the range from low to high includes it.
By their numbers in this assay, from the lowest: compounds 2, 1 and 3 (each within the scatter of the next, the first and the last beyond it).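

In this assay, among these compounds, this is the first pair that differs in one place, and it gives a 1.5-fold higher number from compound 1 to compound 3 (0.16 log units; within the scatter). On a nitrogen on an aromatic ring of the shared core, a cyclohexyl of 6 heavy atoms can therefore give way to a cyclopropyl of 3 heavy atoms without a difference that can be read, so across these two carbon-only rings the read-out does not register ring size. The data offer nothing that explains this result.

On these data alone, it remains open whether an amine or a carboxylic acid carried on this ring, or a longer open chain in its place, would move the number beyond the scatter. A single pair also leaves open whether this holds on cell lines other than the one used here.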